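The compounds below may be only part of what the source reports. "The series", "measured", "known", "first", "only" and "open" are said of these compounds alone.

Of the compounds shown here, three sharing one core have been measured in an ADME assay for permeability, using PAMPA, at pH 7.4; a higher number here means that the compound crosses the layer faster, a lower number that the compound crosses the layer more slowly. Compound 1 `COc1ccc(NC(=O)Nc2cc(C)nc3ccccc23)cc1` gives 787 10^-6 cm/s. Compound 2 `Cc1cc(NC(=O)Nc2cc(F)ccc2F)c2ccccc2n1` gives 541 10^-6 cm/s, and compound 3 `Cc1cc(NC(=O)Nc2ccccc2C(F)(F)F)c2ccccc2n1` gives 945 10^-6 cm/s. These three numbers lie close together: compound 1 sits within the usual scatter of both compound 3 and compound 2, so none of the three can be set apart from the others.

Compound 4 `Cc1ccc(NC(=O)Nc2cc(C)nc3ccccc23)cc1` has not yet been measured in this assay. It differs from compound 1 in one place: methyl in place of methoxy on an aromatic carbon. Within the data shown here, no measured pair shows this change, so the expectation rests on the change alone. A small step is expected, not beyond the scatter, as a 1.1-fold higher number from compound 1 to compound 4 (0.06 log units; within the scatter). For compound 4 the estimate is 900 10^-6 cm/s, expected to fall between 550 10^-6 cm/s and 1400 10^-6 cm/s.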

Compound 4, apparent permeability: 669 10^-6 cm/s
Estimate against measurement, compound 4: 1.3-fold (0.13 log units) above, and the stated range covers the measured number.
By their numbers in this assay, from the lowest: compounds 2, 4, 1 and 3 (each within the scatter of the next).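

In this assay the exchange of methoxy for methyl on an aromatic carbon, para to a large group, gives a 1.2-fold lower number from compound 1 to compound 4 (0.07 log units; within the scatter) and so does not set the two compounds apart. Among these compounds, this is the first pair that differs in one place, which allows this position to be read directly for the first time. Nothing measured here explains the size of this step.

As far as these compounds go, whether an amine, a carboxylic acid or a longer chain at this position would give a step beyond the scatter stays open. So does whether methyl in place of methoxy gives a similar step at other positions.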